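The source may report more compounds than this note shows. Statements on the series, on what has been measured and on what is new or still open speak of the compounds shown alone.

Of the compounds shown here, three from the series have been measured in an assay on isolated protein (Oryctolagus cuniculus) with Thromboxane-A synthase (Homo sapiens) as the target, tested at 1 uM; on this read-out higher numbers stand for more inhibition at the one concentration tested (going by the name of the read-out) and lower numbers for less inhibition. Compound 1 `Oc1nnc(-c2cccnc2)c2ccccc12` gives 26%. Compound 2 `O=c1c2ccccc2c(-c2cccnc2)nn1C1CCCC1` gives 97%, and compound 3 `O=c1c2ccccc2c(-c2cccnc2)nn1S(=O)(=O)c1ccccc1` gives 96%. Compound 2 holds the top number of the three, yet compound 3 sits within the usual scatter of it, while compound 1 lies well beyond the scatter below it. Compound 4 `O=C(O)Cn1nc(-c2cccnc2)c2ccccc2c1=O` is not yet measured; it differs from compound 2 by carboxymethyl in place of cyclopentyl on an aromatic nitrogen. Since compound 2 and compound 3 both give very high inhibition with quite different groups on that nitrogen, only a small downward step is expected in this assay, a number 12 percentage points lower from compound 2 to compound 4 (beyond the scatter). Compound 4 is therefore estimated to give 85%, within a range from 60% to 97%.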

Compound 4, a percentage reported as inhibition, at one concentration (the size of the read-out at that concentration, not a potency): 13%
Beside the measured number, compound 4's estimate is 72 percentage points above it; the whole stated range lies above it.
By their numbers in this assay, from the lowest: compound 4; then compound 1; then compounds 3 and 2 (each within the scatter of the next).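

In this assay, carboxymethyl in place of cyclopentyl on the aromatic nitrogen gives a number 84 percentage points lower from compound 2 to compound 4 (beyond the scatter), a large step. This shows that the position does not accept every group, which the high numbers of compound 2 and compound 3 alone could not show. The data offer no explanation for this step.

The compounds shown leave open whether the carboxylic acid or the loss of the carbon ring matters more, as a methyl ester or plain ethyl group would help separate the two. On these data alone, how a longer chain ending in a carboxylic acid would behave also remains open.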